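A few compounds are considered here, and "the series" means these few. Any claim that something is new, unique, unknown or untested is made for them only; others in the source may bear on it.

Working notes on the series, read in a functional assay on ML1 cells (Homo sapiens) for antiproliferative activity, read by WST assay, with a stated time of 3 days; on this read-out higher numbers stand for weaker inhibition and lower numbers for stronger inhibition. For the measured compounds named here, compound 1 `O=c1cc(I)n([C@@H]2O[C@H](CO)[C@@H](O)[C@H]2O)c(=O)[nH]1` gives 15300 nM, the only actual number so far. Compound 2 `CN(C)c1cc(=O)[nH]c(=O)n1[C@@H]1O[C@H](CO)[C@@H](O)[C@H]1O` gives > 50000 nM, which is a limit of the assay. Compound 3 `O=c1[nH]c(=O)n([C@@H]2O[C@H](CO)[C@@H](O)[C@H]2O)c(I)c1F` gives > 50000 nM, also a limit and not a number. Compound 3 thus stands at the limit of > 50000 nM in this assay, at which 2 of the 3 values shown sit, with no number of its own.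

The change to compound 4 `CCc1c(F)c(=O)[nH]c(=O)n1[C@@H]1O[C@H](CO)[C@@H](O)[C@H]1O` is ethyl in place of iodo on an aromatic carbon. The fluoro group stays, and the new ethyl sits next to the ring nitrogen.

Going by the values given here, two measured steps bear on this. The fluoro group arrived in an at least 3.2-fold higher number from compound 1 to compound 3 (0.51 log units; beyond the scatter), and compound 4 keeps it. The iodo group left in an at least 3.2-fold higher number from compound 1 to compound 2 (0.51 log units; beyond the scatter), with dimethylamino in its place. Both steps run towards weaker inhibition, and the true size of each is open, since each ends at a limit. Neither shows a replacement for iodo that holds the activity of compound 1. In this assay, no recovery is therefore expected on going to ethyl. The expected change is a number no higher from compound 3 to compound 4 (the limit leaves the size open), which is estimated to stay within the scatter. For compound 4 the estimated value is 50000 nM, with an expected range from 25000 nM to 100000 nM.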

Compound 4, half-maximal inhibitory concentration: 2100 nM
Compound 4: the middle estimate sits 24-fold (1.38 log units) above what was measured; measured number outside the range, below it.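

In this assay, ethyl in place of iodo gives an at least 23-fold lower number from compound 3 to compound 4 (1.37 log units; beyond the scatter), the only step shown that runs towards stronger inhibition. The earlier step from iodo to dimethylamino, made without the fluoro group, ended at a limit, so loss of iodo might have seemed enough to lose activity at this position; compound 4 shows that this does not hold for every replacement, at least with a fluoro group ortho to the new ethyl. The size of the new step remains a lower bound only, since compound 3 has a limit and no number of its own: the limit of > 50000 nM in this assay, at which 2 of the 4 values shown sit.

The compounds shown do not tell whether ethyl is a special case at this carbon next to the ring nitrogen, or whether methyl, a propyl chain or cyclopropyl would serve as well. They also leave the part played by the fluoro group unresolved, and an ethyl compound carrying hydrogen in place of fluoro would separate that contribution from the contribution of ethyl itself.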